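The compounds below may be only part of what the source reports. "The series", "measured", "known", "first", "only" and "open" are said of these compounds alone.

Working notes on the aryl sulfonate series. Compound 2 `CCNC(=O)Nc1ccc(S(=O)(=O)Oc2ccccc2I)cc1` stands at 5600 nM in a functional assay on M21 cells (Homo sapiens) for antiproliferative activity, read by sulforhodamine B assay, with a stated time of 48 h (on this read-out higher numbers stand for weaker inhibition and lower numbers for stronger inhibition), the lower of the two numbers recorded so far; its nearest neighbour, compound 1 `CC(=O)Nc1ccc(S(=O)(=O)Oc2ccccc2I)cc1`, gives 27000 nM in this assay. Within the data shown here, the one step measured, a 4.8-fold lower number from compound 1 to compound 2 (0.68 log units; beyond the scatter), exchanged the methyl on the carbonyl carbon for ethylamino. Compound 3 `O=C(NCCCCl)Nc1ccc(S(=O)(=O)Oc2ccccc2I)cc1` is the next compound to be measured in this assay. It differs from compound 2 by chloromethyl in place of hydrogen on a saturated chain carbon, two bonds along the chain from an amide-type nitrogen. The measured step is of a different kind, a change at the carbonyl carbon itself rather than a lengthening of the chain that hangs from the urea nitrogen, so it bears only loosely on the new step and gives no direction for it. The expectation is therefore a step of a 1.4-fold lower number from compound 2 to compound 3 (0.15 log units; within the scatter), with a wide margin. For compound 3 the estimate in this assay is 4000 nM, expected to fall between 1500 nM and 11000 nM.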

Compound 3, half-maximal inhibitory concentration: 4600 nM
Estimate against measurement, compound 3: 1.2-fold (0.06 log units) below, and the stated range covers the measured number.
By their numbers in this assay, from the lowest: compounds 3 and 2 (each within the scatter of the next); then compound 1.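

In this assay, the change from ethylamino to (3-chloropropyl)amino gives a 1.2-fold lower number from compound 2 to compound 3 (0.09 log units; within the scatter) and so shows no readable effect of adding chloromethyl on this saturated chain carbon, two bonds along the chain from an amide-type nitrogen. The advantage over the methyl on the carbonyl carbon remains with the longer chloro-bearing chain, with a 5.9-fold lower number from compound 1 to compound 3 (0.77 log units; beyond the scatter) as the step beyond the scatter. No measurement available here bears on the reason for this result.

On these data alone, the role of the chlorine remains open, since a plain propyl chain would separate it from the added chain length. As far as these compounds go, how far this position extends also remains open, as a longer chain or a terminal amine in place of the chlorine would test different ends on the same urea.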